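The compounds below may be only part of what the source reports. "The series", "measured", "known", "first", "only" and "open" are said of these compounds alone.

Measured in a functional assay on L1210 cells (Mus musculus) for inhibition; a higher number here means a weaker inhibitor, a lower number a stronger inhibitor:
- compound 1 `CN(C)c1ccc(/C=C2\CCc3ccccc3C2=O)cc1` gives 17500 nM
- compound 2 `O=C1/C(=C/c2ccc(F)cc2)CCCc2ccccc21` gives 60300 nM
- compound 3 `O=C1/C(=C/c2cccc([N+](=O)[O-])c2)CCCc2ccccc21` gives 48800 nM

Compound 2 (60300 nM) lies within the scatter of compound 3 (48800 nM), and these two share a core. Compound 1 (17500 nM) has a lower number than compound 2, beyond the scatter, and stands on a different core.

The next compound is compound 4 `CN(C)c1ccc(/C=C2\CCCc3ccccc3C2=O)cc1`, which has dimethylamino in place of fluoro on an aromatic carbon, para to a large group, relative to compound 2 (dimethylamino in place of fluoro on an aromatic carbon).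

Within the data shown here, no measured step isolates this change. Among the measured compounds shown here, the only guide is compound 1 (17500 nM), the one measured compound that carries dimethylamino, and its different core leaves what it can show uncertain. A move toward a lower number is therefore expected, with an estimated size of (a 2.7-fold lower number from compound 2 to compound 4 (0.44 log units; beyond the scatter)) and a modest degree of confidence. Compound 4 is estimated at 22000 nM in this assay, with an expected range of 8000 nM to 60000 nM around that estimate.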

Compound 4, half-maximal inhibitory concentration: 1870 nM
For compound 4 the middle estimate is 12-fold (1.07 log units) above the measured one, outside the stated range (below it).
By their numbers in this assay, from the lowest: compound 4; then compound 1; then compounds 3 and 2 (each within the scatter of the next).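

In this assay, dimethylamino in place of fluoro on an aromatic carbon, para to a large group, gives a 32-fold lower number from compound 2 to compound 4 (1.51 log units; beyond the scatter) on the shared core. Among these compounds, this is the first reading of the exchange with the core held fixed, which the earlier compounds could not provide, and the single change carries a large step. Nothing on hand accounts for the size of this step.

This position is covered by one pair only, so a single step cannot show whether the shift belongs to dimethylamino specifically or extends to related groups. Open questions are whether a primary amine, diethylamino or methoxy at the same place would give a step of similar size, and whether the exchange behaves the same way on the core of compound 1.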